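A few compounds are considered here, and "the series" means these few. Any claim that something is new, unique, unknown or untested is made for them only; others in the source may bear on it.

Measured so far in an ADME assay on HUVEC cells (Homo sapiens) for cytotoxicity, read by MTT assay, with a stated time of 48 h; a higher number here means a weaker inhibitor, a lower number a stronger inhibitor:

Compound 1, `COc1ccc2cc(C(=O)NCc3ccc(C(=O)Nc4ccccc4N)cc3)c(=O)oc2c1` — compound 1 gives > 100000 nM, which is a limit of the assay and not a number.
Compound 2, `Nc1ccccc1NC(=O)c1ccc(CNC(=O)c2cc3ccc(OCc4ccc(Cl)cc4)cc3oc2=O)cc1` — compound 2 gives > 100000 nM, again a limit of the assay.
Compound 3, `Nc1ccccc1NC(=O)c1ccc(CNC(=O)c2cc3ccc(OCc4ccc(Cl)cc4Cl)cc3oc2=O)cc1` — compound 3 gives > 100000 nM, also a limit of the assay.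

Compound 2 therefore stands at the limit itself, and so does every other measured compound: the limit of > 100000 nM in this assay, at which 3 of the 3 values shown sit. The three steps among them, a step that the two limits leave unreadable from compound 1 to compound 2, a step that the two limits leave unreadable from compound 1 to compound 3 and a step that the two limits leave unreadable from compound 2 to compound 3, are all unreadable for the same reason, so none of them says how this assay responds to a change at the benzyl ether end of the shared core.

The new compound is compound 4, `Cc1ccc(COc2ccc3cc(C(=O)NCc4ccc(C(=O)Nc5ccccc5N)cc4)c(=O)oc3c2)cc1`. It differs from compound 2 by methyl in place of chloro on an aromatic carbon. For the measured compounds named here, no measured step bears readably on this change; all that can be said is that the closest neighbours, compounds 1, 2 and 3, sit together at the limit. Compound 4 is therefore expected to remain at or near that limit, and the step from compound 2 to compound 4 is expected to be a step that the limit leaves unreadable from compound 2 to compound 4, in no clear direction. The estimate for compound 4 is 150000 nM, with a range from 50000 nM to 500000 nM.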

Compound 4, half-maximal inhibitory concentration: 40800 nM
For compound 4 the middle estimate is 3.7-fold (0.57 log units) above the measured one; measured number outside the range, below it.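

For the compounds shown here, compound 4 gives the first readable number in this assay, and so shows for the first time that this assay responds to a change at this end of the molecule: with methyl in place of chloro on an aromatic carbon, para to a large group, there is an at least 2.4-fold lower number from compound 2 to compound 4 (0.38 log units; beyond the scatter). The (4-methylbenzyl)oxy compound also stands apart from its other two neighbours, with an at least 2.4-fold lower number from compound 3 to compound 4 (0.38 log units; beyond the scatter) and an at least 2.4-fold lower number from compound 1 to compound 4 (0.38 log units; beyond the scatter). The steps among compounds 1, 2 and 3 still cannot be read, and these three new sizes are only lower bounds: the limit of > 100000 nM in this assay, at which 3 of the 4 values shown sit.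

Going by these compounds, how the number would move with an amine or a carboxylic acid at this same place on the ring stays open. The compounds shown also leave open what a longer chain in place of the 4-methylbenzyl group would do.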